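The source may hold more compounds than are shown below. What is called first, only, known or untested is meant among the compounds shown, and "the series" means these compounds.

Measured in an ADME assay on MRC5 cells (Homo sapiens), read by MTT assay, with a stated time of 72 h; on this read-out lower numbers stand for stronger inhibition and higher numbers for weaker inhibition:
Compound 1 `COc1ncnc2c1c(-c1cccs1)cn2[C@@H]1O[C@H](CO)[C@@H](O)[C@H]1O` gives 43200 nM.
Compound 2 `COc1ncnc2c1c(-c1ccccc1)cn2[C@@H]1O[C@H](CO)[C@@H](O)[C@H]1O` gives only the assay limit > 100000 nM.
Compound 3 `CNc1ncnc2c1c(-c1ccoc1)cn2[C@@H]1O[C@H](CO)[C@@H](O)[C@H]1O` gives only the assay limit > 100000 nM.

Compound 3 thus stands at the limit of the assay and carries no number; it sits at the limit of > 100000 nM in this assay, at which 2 of the 3 values shown sit. Only compound 1 gives a number, and that number already means weak inhibition. The move to compound 4 `COc1ncnc2c1c(-c1ccoc1)cn2[C@@H]1O[C@H](CO)[C@@H](O)[C@H]1O` is a change at a single position: methoxy in place of methylamino on an aromatic carbon. Among the measured compounds shown here, only one measured step exists, an at least 2.3-fold higher number from compound 1 to compound 2 (0.36 log units; beyond the scatter), and it swaps phenyl for thiophen-2-yl while the methoxy group stays the same. No measured step therefore bears directly on the exchange of methylamino for methoxy, and the size of the step from compound 3 to compound 4 cannot be read from the data shown. What the data do show is that both methoxy-bearing compounds, compound 1 and compound 2, inhibit weakly at best, and compound 3 sits at the limit. The expectation for compound 4 is accordingly weak inhibition again, with a fair chance that only a limit is reported. Compound 4 is estimated at 80000 nM, with a range from 30000 nM to 200000 nM. The step from compound 3 to compound 4 is expected to be an at least 1.2-fold lower number from compound 3 to compound 4 (0.09 log units; that floor lies within the scatter).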

Compound 4, half-maximal inhibitory concentration: 29400 nM
The estimate for compound 4 lay 2.7-fold (0.43 log units) above the measured number; the measured number lies below the stated range.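

The exchange of methylamino for methoxy, on the aromatic carbon next to the ring nitrogen, now has its first direct reading in this assay: with furan-3-yl kept in place, the change gives an at least 3.4-fold lower number from compound 3 to compound 4 (0.53 log units; beyond the scatter). With methoxy kept in place, furan-3-yl in place of phenyl gives an at least 3.4-fold lower number from compound 2 to compound 4 (0.53 log units; beyond the scatter), while furan-3-yl in place of thiophen-2-yl gives a 1.5-fold lower number from compound 1 to compound 4 (0.17 log units; within the scatter), so furan-3-yl and thiophen-2-yl cannot be told apart here, and among these methoxy compounds phenyl alone separates from furan-3-yl. Compound 2 and compound 3 each carry only a limit and not a number, so the two steps that start from them give only a floor, and their full size stays unknown: the limit of > 100000 nM in this assay, at which 2 of the 4 values shown sit.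

Among the compounds shown here, the exchange at this position is seen only with furan-3-yl, so whether methoxy would also give a lower number than methylamino alongside phenyl or thiophen-2-yl remains open. On these data alone, it is also open how a plain amine, a dimethylamino group or a longer ethoxy chain at the same carbon would compare, and whether the missing hydrogen-bond donor of methoxy has any part in the step.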